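This account rests on a few compounds, and the source may have more. Where it says the series, first, only, none or still open, it means among the compounds named here.

Compound 1 `CS(=O)(=O)c1ccc(Cc2n[nH]c(=S)n2/N=C/c2cccnc2)cc1` and compound 2 `CS(=O)(=O)c1ccc(Cc2n[nH]c(=S)n2/N=C/c2ccc(F)cc2)cc1` share one core and differ only in the aromatic ring that hangs from a carbon with a double bond to nitrogen. In a functional assay on HeLa cells (Homo sapiens) for cytotoxicity, read by MTT assay, with a stated time of 48 h, tested at 12.5 uM (a lower number here means a weaker effect, a higher number a stronger effect of the compound at the concentration tested), compound 1 gives 16.9%, and compound 2 gives 2.8%. Going by the values given here, the single measured step between them is a number 14.1 percentage points lower from compound 1 to compound 2 (beyond the scatter). On these two numbers compound 2 stands lowest, with compound 1 as the nearest value and the gap beyond the scatter.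

Compound 3 `CS(=O)(=O)c1ccc(Cc2n[nH]c(=S)n2/N=C/c2ccccc2F)cc1` keeps every atom of compound 2 and rearranges one ring: 2-fluorophenyl in place of 4-fluorophenyl on a carbon with a double bond to nitrogen. Among the compounds with values here, no measured step covers a change of this kind; the only step on hand swaps a pyridin-3-yl for a 4-fluorophenyl, and it gives no guide to how a 2-fluorophenyl compares with a 4-fluorophenyl. With nothing to point either way, the expected step in this assay is a number 3.2 percentage points higher from compound 2 to compound 3 (within the scatter), which is within the usual scatter. Compound 3 is therefore estimated at 6%, with a range from 0% to 20%.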

Compound 3, a percentage reported as activity, at one concentration (the size of the read-out at that concentration, not a potency): 16.5%
Estimate against measurement, compound 3: 10.5 percentage points below; low and high end bracket the measured number.
By their numbers in this assay, from the lowest: compound 2; then compounds 3 and 1 (each within the scatter of the next).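

Swapping 4-fluorophenyl for 2-fluorophenyl on the carbon with a double bond to nitrogen leaves the atom count unchanged, yet this assay shows a number 13.7 percentage points higher from compound 2 to compound 3 (beyond the scatter), so at this position the read-out depends on where the fluorine sits on the ring and not only on its presence. Replacing pyridin-3-yl with 2-fluorophenyl gives a number 0.4 percentage points lower from compound 1 to compound 3 (within the scatter). Among these three compounds only the 4-fluorophenyl ring stands apart. Nothing available explains why the two fluorine placements differ.

The compounds shown leave open how a 3-fluorophenyl ring or a plain phenyl ring would compare, and whether a chlorine or a methoxy group would follow the same dependence on placement as fluorine. All of these numbers also come from a single concentration, so they show only a stronger or weaker effect at that concentration.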